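Moving the carboxylate from para to meta on the benzyl arm

The source may hold more compounds than are shown below. What is called first, only, known or untested is meant among the compounds shown, and "the series" means these compounds.

Measured compounds:
Compound 1 `Cc1cc(OCc2c(-c3c(Cl)cccc3Cl)noc2C(C)C)nc2ccccc12` gives 104%.
Compound 2 `CCN(Cc1ccc(C(=O)O)cc1)c1ccc(OCc2c(-c3c(Cl)cccc3Cl)noc2C2CC2)nc1C(F)(F)F` gives 94%.
Compound 3 `CC(C)c1onc(-c2c(Cl)cccc2Cl)c1COc1cnc(N(C)Cc2ccc(C(=O)O)cc2)c(Cl)c1` gives 103%.

The three compounds were examined in an assay on isolated protein for agonist activity at Bile acid receptor (Homo sapiens), read by FRET (on this read-out higher numbers stand for larger maximal responses and lower numbers for smaller maximal responses), and all of them reach a largest response close to that of the reference. Compound 3 stands in the middle of the three numbers: the number of compound 1 lies one point higher and that of compound 2 nine points lower, and both gaps are within the usual scatter of repeated measurements. No two of the three differ in only one place, so their numbers can only be read side by side, and read that way they show no separation at all.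

Compound 4 `CC(C)c1onc(-c2c(Cl)cccc2Cl)c1COc1cnc(N(C)Cc2cccc(C(=O)O)c2)c(Cl)c1` is built from compound 3 with a single rearrangement: 3-carboxyphenyl in place of 4-carboxyphenyl on a saturated chain carbon bound to a nitrogen on an aromatic ring. The carboxylic acid stays on the same ring and the shared core is untouched. Since every compound shown so far reaches the reference level in this assay regardless of how the acid-bearing arm is fitted, the step from compound 3 to compound 4 is expected to be small and not beyond the scatter: a number 3 percentage points lower from compound 3 to compound 4 (within the scatter). Compound 4 is therefore estimated at 100%, with a range from 85% to 112%.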

Compound 4, largest response reached (reported as efficacy), in percent of the reference or control that the assay uses: 105%
The estimate for compound 4 lay 5 percentage points below the measured number; the measured number falls inside the stated range.
By their numbers in this assay, from the lowest: compounds 2, 3, 1 and 4 (each within the scatter of the next, the first and the last beyond it).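

In this assay the change is a number 2 percentage points higher from compound 3 to compound 4 (within the scatter) and so, on a saturated chain carbon bound to a nitrogen on an aromatic ring, 3-carboxyphenyl and 4-carboxyphenyl cannot be told apart by largest response. Among the compounds shown here, this pair is the first that differs in one place, and it gives a direct comparison where the earlier compounds could only be read side by side: with the shared core and the rest of the arm held fixed, changing where the carboxylic acid sits on this ring leaves the response close to that of the reference. No available evidence bears on why the largest response holds across this change.

Still open, as far as these compounds go, is whether the response would hold if a tetrazole or a primary amide replaced the carboxylic acid, or if the acid were carried on a longer chain than the benzyl arm. From the compounds shown here alone, this read-out also records only the top of the response, so whether the two arms need similar concentrations to reach it remains unknown.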